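Replacing the anilino aryl group in a dichlorophenyl urea series

The compounds below may be only part of what the source reports. "The series", "measured", "known", "first", "only" and "open" are said of these compounds alone.

Three compounds share a core built from a pyrimidine-type ring carrying a urea on one side and an arylamino group on the other. Compound 1 `COc1cc(NC(=O)Nc2cc(Nc3ccc(OC)c(C)c3)ncn2)cc(OC)c1` gives 62% in a functional assay on PC-9 cells (Homo sapiens) for inhibition, read by MTT assay, with a stated time of 48 h, tested at 10 uM; on this read-out lower numbers stand for less inhibition and higher numbers for more inhibition at the one concentration tested (going by the name of the read-out). Compound 2 `COc1ccc(OC)c(Nc2cc(NC(=O)Nc3c(Cl)cccc3Cl)ncn2)c1` gives 95% in this assay, and compound 3 `COc1cc(Br)ccc1Nc1cc(NC(=O)Nc2c(Cl)cccc2Cl)ncn1` gives 90.5%. Compound 3 thus stands second highest of the three numbers: its value and that of compound 2 lie within the scatter of each other, while compound 1 lies well below it, beyond the scatter.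

Compound 4 `Cc1ccc(Nc2cc(NC(=O)Nc3c(Cl)cccc3Cl)ncn2)cc1C` has not yet been measured. It differs from compound 3 in one place: 3,4-dimethylphenyl in place of 4-bromo-2-methoxyphenyl on a nitrogen on an aromatic ring. The urea side that compounds 2 and 3 share is kept. Since both of those compounds show high inhibition in this assay regardless of the arylamino group, compound 4 is expected to stay near that level, with at most a small drop, giving an expected step of a number 5.5 percentage points lower from compound 3 to compound 4 (within the scatter) that lies within the scatter. Compound 4 is estimated at 85% with a likely range from 65% to 97%.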

Compound 4, a percentage reported as inhibition, at one concentration (the size of the read-out at that concentration, not a potency): 92.1%
Beside the measured number, compound 4's estimate is 7.1 percentage points below it; low and high end bracket the measured number.
By their numbers in this assay, from the lowest: compound 1; then compounds 3, 4 and 2 (each within the scatter of the next).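

In this assay, putting 3,4-dimethylphenyl in place of 4-bromo-2-methoxyphenyl on a nitrogen on an aromatic ring gives a number 1.6 percentage points higher from compound 3 to compound 4 (within the scatter), so this position accepts a clear change of group without a measurable difference in the read-out. Among the compounds shown here, the bromine and the oxygen both leave, and the hydrogen-bond acceptor of the old group has no counterpart in the new one, yet in this pair inhibition remains high without them. Nothing available explains why the two groups read alike.

Still open, as far as these compounds go, is whether this holds for a ring carrying a carboxylic acid or an amine, or for a longer chain in place of the ring. A reading at one concentration is not a potency, so compound 3 and compound 4 might still separate at lower concentrations.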